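Swapping the benzyl arm for a butyl chain on the triazole

The source may report more compounds than this note shows. Statements on the series, on what has been measured and on what is new or still open speak of the compounds shown alone.

The shared core of compound 1 `O=C1C[C@H](OCc2cn(Cc3ccccc3)nn2)[C@H]2CO[C@@H]1O2` carries a triazole whose aromatic nitrogen bears a benzyl group. In a functional assay on MDA-MB-231 cells (Homo sapiens) for cytotoxicity, read by MTT assay, with a stated time of 48 h (on this read-out higher numbers stand for weaker inhibition and lower numbers for stronger inhibition), compound 1 gives > 50000 nM, which is a limit of the assay and not a number; it is the only one of the three measured compounds sitting at that limit (the limit of > 50000 nM in this assay, at which 1 of the 3 values shown sits). Compound 2 `O=C1C[C@H](OCc2cn(C(=O)c3ccccc3)nn2)[C@H]2CO[C@@H]1O2`, with benzoyl on that nitrogen, gives 25900 nM in this assay, and compound 3 `O=C1C[C@H](OCc2cn(-c3ccc(Cl)cc3)nn2)[C@H]2CO[C@@H]1O2`, with 4-chlorophenyl there, gives 26100 nM. The steps of an at least 1.9-fold lower number from compound 1 to compound 2 (0.28 log units; that floor lies within the scatter) and an at least 1.9-fold lower number from compound 1 to compound 3 (0.28 log units; that floor lies within the scatter) are both floored by the limit, and compound 2 against compound 3 shows a 1.0-fold higher number from compound 2 to compound 3 (0.00 log units; within the scatter).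

Compound 4 `CCCCn1cc(CO[C@H]2CC(=O)[C@@H]3OC[C@H]2O3)nn1` differs from compound 1 in a different way: propyl in place of phenyl on a saturated chain carbon bound to an aromatic nitrogen. No measured step swaps an aromatic ring for a plain chain, so nothing shown speaks directly to this change. The expectation is therefore that compound 4 stays near the limit, with a step of a number no higher from compound 1 to compound 4 (the limit leaves the size open) expected, and its estimated value is 50000 nM, ranging from 20000 nM to 120000 nM.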

Compound 4, half-maximal inhibitory concentration: 27900 nM
Compound 4: the middle estimate sits 1.8-fold (0.25 log units) above what was measured, and the stated range covers the measured number.
By their numbers in this assay, from the lowest: compounds 2, 3 and 4 (each within the scatter of the next). At a limit, above all of these: compound 1.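

In this assay, the butyl chain of compound 4 carries no ring, yet this compound gives a measured number, with the step reading an at least 1.7-fold lower number from compound 1 to compound 4 (0.25 log units; that floor lies within the scatter). A ring on this nitrogen is therefore not needed for a measured number, and the plain chain cannot be told apart from the two groups with aromatic rings: the steps are a 1.1-fold higher number from compound 3 to compound 4 (0.03 log units; within the scatter) and a 1.1-fold higher number from compound 2 to compound 4 (0.03 log units; within the scatter). Within the data shown here, compound 1, with its benzyl group, remains the only compound at a limit of the assay: the limit of > 50000 nM in this assay, at which 1 of the 4 values shown sits.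

As far as these compounds go, what separates benzyl from butyl, benzoyl and 4-chlorophenyl remains open, since only compound 1 sits at the limit. Also open, from the compounds shown here alone, is whether a longer chain such as octyl, or an amine or a carboxylic acid at the end of the butyl chain, would shift the number beyond the scatter.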